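The compounds below may be only part of what the source reports. "The series", "measured", "known", "first", "only" and "open" are said of these compounds alone.

Measured so far:
compound 1 `O=C1N/C(=N/c2ccc(Cl)cc2)S/C1=C\c1ccccn1` — 41.7%
compound 2 `COc1ccc(/N=C2\NC(=O)/C(=C/c3ccccn3)S2)cc1` — 42.4%

In a functional assay on the whole organism (strain Swiss albino) for inhibition, with Mus musculus as the target, in the writhing test, with stated times of 30 min and 15 min, at a dose of 50 mg/kg by the oral route (a lower number here means less inhibition, a higher number more inhibition at the dose given (going by the name of the read-out)), compound 1 gives 41.7%, the lower of the two numbers shown. Compound 2 gives 42.4%, which lies within the scatter of compound 1, so the two are not separated. Compound 3 `Cc1ccccc1/N=C1/NC(=O)/C(=C/c2ccccn2)S1` is not yet measured. It differs from compound 1 in one place: 2-methylphenyl in place of 4-chlorophenyl on a double-bonded nitrogen. Within the data shown here, no measured pair shows a change of this kind, so the size of the step in this assay is open; nothing in the two numbers points to a change beyond the scatter in either direction. For compound 3 the expected inhibition is 40%, in a range from 25% to 55%. The expected step is a number 1.7 percentage points lower from compound 1 to compound 3 (within the scatter), estimated as lying within the scatter.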

Compound 3, a percentage reported as inhibition, in the whole organism at one dose (the size of the read-out at that dose, not a potency): 43.6%
The estimate for compound 3 lay 3.6 percentage points below the measured number, and the stated range covers the measured number.
By their numbers in this assay, from the lowest: compounds 1, 2 and 3 (each within the scatter of the next).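

In this assay, 2-methylphenyl in place of 4-chlorophenyl on a double-bonded nitrogen gives a number 1.9 percentage points higher from compound 1 to compound 3 (within the scatter). Among these compounds, this is the first reading of a change at this position, and the exchange leaves the read-out unseparated at the dose given. No available data bear on why the step is this size.

On these data alone, whether an amine or a carboxylic acid on the phenyl ring would carry the inhibition beyond the scatter remains open. The same holds for a longer chain in place of the ring.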